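Removing Two Methyls: Expected Permeability of Compound 4

The source may hold more compounds than are shown below. What is called first, only, known or untested is meant among the compounds shown, and "the series" means these compounds.

Compound 1 `COc1ccccc1Oc1ccc2c(NCCCNCc3ccco3)ccnc2c1`: 317 10^-6 cm/s
Compound 2 `COc1ccc(F)cc1CNCCCNc1ccnc2cc(Cc3cc(C)cc(C)c3)ccc12`: 23 10^-6 cm/s
Compound 3 `Cc1cc(C)cc(Cc2ccc3c(NCCCNCc4ccco4)ccnc3c2)c1`: 23 10^-6 cm/s

In an ADME assay for permeability, using PAMPA, with a stated time of 30 min, at pH 7.4 (a lower number here means that the compound crosses the layer more slowly, a higher number that the compound crosses the layer faster), compound 2 stands level with compound 3 at the digits given, and together they are the lowest of the three numbers; compound 1 gives the highest. Among the compounds with values here, the one large step seen is a 14-fold lower number from compound 1 to compound 3 (1.14 log units; beyond the scatter), while no change at the digits printed from compound 2 to compound 3 (within the scatter) shows that swapping the group on the amine end leaves the number where it was.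

Compound 4 `COc1ccc(F)cc1CNCCCNc1ccnc2cc(Cc3ccccc3)ccc12` differs from compound 2 by phenyl in place of 3,5-dimethylphenyl on a saturated chain carbon bound to an aromatic carbon. Neither measured step touches this part of the molecule, so there is no direct guide. Compound 4 is therefore expected to sit close to compound 2, a step of a 1.1-fold higher number from compound 2 to compound 4 (0.04 log units; within the scatter). The estimate for compound 4 is 25 10^-6 cm/s, within a range of 10 10^-6 cm/s to 60 10^-6 cm/s.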

Compound 4, apparent permeability: 23 10^-6 cm/s
Beside the measured number, compound 4's estimate is 1.1-fold (0.04 log units) above it; the range from low to high includes it.
By their numbers in this assay, from the lowest: compounds 2, 3 and 4 (each within the scatter of the next); then compound 1.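

Going from 3,5-dimethylbenzyl to benzyl, a change the earlier steps never touched, gives no change at the digits printed from compound 2 to compound 4 (within the scatter) in this assay. For this pair, then, the phenyl on a saturated chain carbon bound to an aromatic carbon gives the same reading with or without its two methyls. No measurement at hand explains why the number holds.

From the compounds shown here alone, whether an amine or a carboxylic acid on that phenyl, or a longer chain in its place, would shift the number remains open. So does whether the same change behaves alike in a compound carrying furan-2-yl.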